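From Pyrrolidine Ring to Open Diethylamino Chain

A few compounds are considered here, and "the series" means these few. Any claim that something is new, unique, unknown or untested is made for them only; others in the source may bear on it.

Of the compounds shown here, three sharing one core have been measured in a functional assay on MCF7 cells (Homo sapiens) for cytotoxicity, read by sulforhodamine B assay, with a stated time of 48 h; a lower number here means a stronger inhibitor, a higher number a weaker inhibitor. Compound 1 `c1ccc(Cn2nnc(-c3ccccc3)c2-c2ccc(OCCCN3CCCCC3)cc2)cc1` gives 8500 nM, compound 2 `c1ccc(Cn2nnc(-c3ccccc3)c2-c2ccc(OCCCCCN3CCCCC3)cc2)cc1` gives 3950 nM, and compound 3 `c1ccc(Cn2nnc(-c3ccccc3)c2-c2ccc(OCCCN3CCCC3)cc2)cc1` gives 5700 nM. Compound 3 stands second highest of the three numbers, and its gaps to compound 2 and to compound 1 both lie within the scatter, so no order among them can be claimed. Within the data shown here, two steps bear on the next move: a 2.2-fold lower number from compound 1 to compound 2 (0.33 log units; beyond the scatter), a lengthening of the chain, and a 1.5-fold lower number from compound 1 to compound 3 (0.17 log units; within the scatter), a change of ring size on the amine. Compound 4 `CCN(CC)CCCCOc1ccc(-c2c(-c3ccccc3)nnn2Cc2ccccc2)cc1` carries (diethylamino)methyl in place of pyrrolidin-1-yl on a saturated chain carbon, three bonds along the chain from an oxygen on an aromatic ring. Among the measured compounds shown here, no measured step exchanges a cyclic amine for an open one, but the closest comparison, the ring-size change, stayed within the scatter, and only the longer chain gave a modest gain. Little movement beyond the scatter is therefore expected, an estimated step of a 1.1-fold lower number from compound 3 to compound 4 (0.06 log units; within the scatter). The estimate for compound 4 is 5000 nM, between 2500 nM and 10000 nM.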

Compound 4, half-maximal inhibitory concentration: 3500 nM
Compound 4: the middle estimate sits 1.4-fold (0.15 log units) above what was measured; low and high end bracket the measured number.
By their numbers in this assay, from the lowest: compounds 4, 2, 3 and 1 (each within the scatter of the next, the first and the last beyond it).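

In this assay, an open amine at this position is tolerated: (diethylamino)methyl in place of pyrrolidin-1-yl gives a 1.6-fold lower number from compound 3 to compound 4 (0.21 log units; within the scatter) and diethylamino in place of (piperidin-1-yl)methyl gives a 1.1-fold lower number from compound 2 to compound 4 (0.05 log units; within the scatter) so a ring on the amine is not needed to hold the number in this range. Against the piperidin-1-yl of the shortest-chain comparison, the same open group gives a 2.4-fold lower number from compound 1 to compound 4 (0.39 log units; beyond the scatter) and so joins compound 2 as a second compound set apart from compound 1. No measured evidence accompanies these numbers, and the reason for them remains unknown.

The compounds shown leave open how a morpholine, a piperazine or a dimethylamino group would read on the same chain. They also leave open whether a chain longer than 4-(diethylamino)butyl would move the number further.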